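Adding a Methoxy Group: Three Measured Compounds, One Expected

The source may hold more compounds than are shown below. What is called first, only, known or untested is meant among the compounds shown, and "the series" means these compounds.

Compound 3 `COc1ccc(-c2cc(/C=C/C(=O)c3ccc(N)cc3)[nH]n2)cc1OC` and compound 1 `COc1cc(-c2cc(/C=C/C(=O)c3ccc(N)cc3)[nH]n2)cc(OC)c1OC` share a core, and compound 1 differs from compound 3 only by methoxy in place of hydrogen on an aromatic carbon. In a functional assay on BT-549 cells (Homo sapiens) for inhibition, read by sulforhodamine B assay, with a stated time of 48 h (a higher number here means that more compound is tolerated, a lower number that less compound is tolerated), compound 3 gives 5770 nM, and compound 1 gives 5760 nM, a step of a 1.0-fold lower number from compound 3 to compound 1 (0.00 log units; within the scatter). Compound 2 `COc1ccc(C(=O)/C=C/c2cc(-c3cc(OC)c(OC)c(OC)c3)n[nH]2)cc1OC` gives 5870 nM in this assay; how its core differs from that of compound 3 is not broken down here, and the step of a 1.0-fold higher number from compound 1 to compound 2 (0.01 log units; within the scatter) is likewise small. Compound 4 `COc1cc(C(=O)/C=C/c2cc(-c3cc(OC)c(OC)c(OC)c3)n[nH]2)cc(OC)c1OC` has not yet been measured and differs from compound 2 by methoxy in place of hydrogen on an aromatic carbon, the same change that leads from compound 3 to compound 1. Compound 4 is expected to show a step of a 1.0-fold lower number from compound 2 to compound 4 (0.01 log units; within the scatter) because the earlier step was a 1.0-fold lower number from compound 3 to compound 1 (0.00 log units; within the scatter). Compound 4 is therefore estimated at 5800 nM in this assay, likely between 2900 nM and 11600 nM.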

Compound 4, concentration lethal to 50% of the cells: 5600 nM
Estimate against measurement, compound 4: 1.0-fold (0.02 log units) above, and the stated range covers the measured number.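

In this assay, methoxy in place of hydrogen on an aromatic carbon gives a 1.0-fold lower number from compound 2 to compound 4 (0.02 log units; within the scatter), and the change reads the same on both cores: the same change on two cores in this assay, a 1.0-fold lower number (0.00 log units; within the scatter) from compound 3 to compound 1 and a 1.0-fold lower number (0.02 log units; within the scatter) from compound 2 to compound 4, 1.0-fold (0.02 log units) apart, within the scatter of two such steps

This shows that, on these two cores, the added methoxy group leaves the number within the usual scatter of repeated measurements. It does not show that a change with a clear effect would carry over in the same way, and two cores are too few to make a rule for the whole series.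

The compounds shown leave open what a hydroxyl group, a fluorine atom or a longer chain such as ethoxy would do on the same aromatic ring. They also leave open whether the methoxy result holds on other cores.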